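Tert-butyl for methylsulfanyl on the stilbene-type series

The compounds below may be only part of what the source reports. "The series", "measured", "known", "first", "only" and "open" are said of these compounds alone.

Measured so far in a functional assay on A549 cells (Homo sapiens) for cytotoxicity (on this read-out higher numbers stand for an effect only at larger amounts of compound and lower numbers for an effect already at smaller amounts), as follows:
- compound 1 `COc1cc(/C=C\c2ccc(C(C)(C)C)cc2)cc(OC)c1OC` gives 1.02 uM
- compound 2 `CCOc1ccc(/C=C/c2cc(OC)c(OC)c(OC)c2)cc1` gives 1.7 uM
- compound 3 `COc1cc(/C=C/c2ccc(SC)cc2)cc(OC)c1OC` gives 4.7 uM

Compound 3 has the highest number of the three, with compound 2 nearest and compound 1 furthest. The next change, to compound 4 `COc1cc(/C=C/c2ccc(C(C)(C)C)cc2)cc(OC)c1OC`, is tert-butyl in place of methylsulfanyl on an aromatic carbon and amounts to tert-butyl in place of methylsulfanyl on an aromatic carbon, para to a large group. Within the data shown here, one measured step bears on it directly: a 2.8-fold higher number from compound 2 to compound 3 (0.44 log units; beyond the scatter) when methylsulfanyl replaced ethoxy at this place. Compound 1 carries the same tert-butyl and gives 1.02 uM in this assay but differs from compound 4 in the geometry of its double bond, so it is only a loose guide. A step of similar or smaller size is therefore expected, towards a lower number, and it may stay within the scatter. The expected change is a 1.6-fold lower number from compound 3 to compound 4 (0.19 log units; within the scatter) on this estimate. For compound 4 the estimated value is 3 uM with an expected range from 1 uM to 10 uM in this series.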

Compound 4, concentration for half-maximal effect: > 25 uM
Compound 4 was reported as a limit; the forecaster's own chance of this, stated with the estimate: 5%; middle value at least 8.3-fold (0.92 log units) away from the limit.
By their numbers in this assay, from the lowest: compounds 1 and 2 (each within the scatter of the next); then compound 3. At a limit, above all of these: compound 4.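

In this assay compound 4 stands only as a limit, > 25 uM. At this place, para to a large group, the earlier step of a 2.8-fold higher number from compound 2 to compound 3 (0.44 log units; beyond the scatter) gave no sign of how much the group can matter: tert-butyl gives an at least 5.3-fold higher number from compound 3 to compound 4 (0.72 log units; beyond the scatter), and against ethoxy it gives an at least 14-fold higher number from compound 2 to compound 4 (1.16 log units; beyond the scatter). Tert-butyl alone therefore does not set the read-out, and the step of an at least 24-fold higher number from compound 1 to compound 4 (1.38 log units; beyond the scatter) can be laid on the double bond because nothing else separates these two compounds: the fact that compounds 1 and 4 differ only in the configuration as drawn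

From the compounds shown here alone, how far the true value of compound 4 lies beyond its limit stays open, and so does the real size of all three new steps. Also open, going by these compounds, is whether the double-bond configuration matters as much with ethoxy or methylsulfanyl, and how an amine or a carboxylic acid would read at this place.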